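The source may report more compounds than this note shows. Statements on the series, on what has been measured and on what is new or still open speak of the compounds shown alone.

Three compounds share one core and differ only in the aryl group on a double-bonded chain carbon bound to a double-bonded chain carbon. In an ADME assay on the whole organism for cytotoxicity, with Artemia salina as the target, with a stated time of 24 h (a higher number here means that more compound is needed for the effect, a lower number that less compound is needed), compound 1 `CCOc1cc(/C=C/C(=O)c2ccccc2NC(=O)NS(=O)(=O)c2ccc(C)cc2)ccc1O` gives 19.2 ug/mL, compound 2 `Cc1ccc(S(=O)(=O)NC(=O)Nc2ccccc2C(=O)/C=C/c2cccc([N+](=O)[O-])c2)cc1` gives 44.5 ug/mL, and compound 3 `Cc1ccc(S(=O)(=O)NC(=O)Nc2ccccc2C(=O)/C=C/c2cccnc2)cc1` gives 14.1 ug/mL. Compound 3 has the lowest number of the three, yet a 1.4-fold lower number from compound 1 to compound 3 (0.13 log units; within the scatter), so only a 3.2-fold lower number from compound 2 to compound 3 (0.50 log units; beyond the scatter) sets it apart. Compound 4 `Cc1ccc(S(=O)(=O)NC(=O)Nc2ccccc2C(=O)/C=C/c2ccncc2)cc1` is the next step: pyridin-4-yl in place of pyridin-3-yl on a double-bonded chain carbon bound to a double-bonded chain carbon. For the measured compounds named here, no measured step moves the ring nitrogen alone; the steps to compound 3 exchange whole groups, so they give no direct guide. The expectation is a step of a 1.0-fold lower number from compound 3 to compound 4 (0.00 log units; within the scatter), within the scatter. Compound 4 is estimated at 14 ug/mL, with a range from 7 ug/mL to 28 ug/mL.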

Compound 4, concentration for half-maximal effect: 16.8 ug/mL
The estimate for compound 4 lay 1.2-fold (0.08 log units) below the measured number; the range from low to high includes it.
By their numbers in this assay, from the lowest: compounds 3, 4 and 1 (each within the scatter of the next); then compound 2.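

In this assay moving only the ring nitrogen gives a 1.2-fold higher number from compound 3 to compound 4 (0.08 log units; within the scatter) so the two pyridines cannot be told apart at this position. Compound 4 also cannot be told apart from the compound carrying 3-ethoxy-4-hydroxyphenyl, with a 1.1-fold lower number from compound 1 to compound 4 (0.06 log units; within the scatter) while a second pyridine now separates from 3-nitrophenyl, with a 2.6-fold lower number from compound 2 to compound 4 (0.42 log units; beyond the scatter) and compound 2 stays alone among the four. No measured evidence bears on why these steps come out this way. The compounds shown leave open whether pyridin-2-yl or an aminophenyl group in this place would group with compound 2 or with the other three.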